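Imidazole series at the bombesin subtype-3 receptor: alkyl versus aryl

The source may hold more compounds than are shown below. What is called first, only, known or untested is meant among the compounds shown, and "the series" means these compounds.

Three compounds of the series have numbers in an in vitro functional assay on cells for agonist activity at Bombesin receptor subtype-3 (Homo sapiens), read by luminescence and calcium flux; on this read-out lower numbers stand for an effect already at smaller amounts and higher numbers for an effect only at larger amounts of compound. Compound 1 `O=C(O)c1ccccc1-c1ccc(CCc2ncc(CC3CCCC3)[nH]2)cc1` gives 133 nM. Compound 2 `Cc1cccc(Cc2cnc(CCc3ccc(-c4ccccc4C(=O)O)cc3)[nH]2)c1` gives 4310 nM. Compound 3 `N#Cc1cccc(Cc2cnc(CCc3ccc(-c4ccccc4C(=O)O)cc3)[nH]2)c1` gives 812 nM, the second highest of the three numbers; the step of a 5.3-fold lower number from compound 2 to compound 3 (0.72 log units; beyond the scatter) separates it from compound 2, and the step of a 6.1-fold higher number from compound 1 to compound 3 (0.79 log units; beyond the scatter) from compound 1.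

The next compound, compound 4 `CC(C)(C)CCc1cnc(CCc2ccc(-c3ccccc3C(=O)O)cc2)[nH]1`, differs from compound 3 by neopentyl in place of 3-cyanophenyl on a saturated chain carbon bound to an aromatic carbon. Going by the values given here, two measured steps bear on this change, both starting from the cyclopentyl of compound 1: a 32-fold higher number from compound 1 to compound 2 (1.51 log units; beyond the scatter) and a 6.1-fold higher number from compound 1 to compound 3 (0.79 log units; beyond the scatter). In both, a six-membered aromatic ring in place of a group without an aromatic ring at this position gave a higher number, and the cyanophenyl case was the smaller of the two. Compound 4 returns to a group with no ring at the same place, so the step is expected to run downward, with a size in this assay similar to the step from compound 1 to compound 3, reversed: a 3.2-fold lower number from compound 3 to compound 4 (0.51 log units; beyond the scatter) is the expectation.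

Compound 4 is therefore estimated at 250 nM in this assay, within a range from 80 nM to 800 nM.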

Compound 4, half-maximal effective concentration: 39 nM
Beside the measured number, compound 4's estimate is 6.4-fold (0.81 log units) above it; measured number outside the range, below it.
By their numbers in this assay, from the lowest: compound 4; then compound 1; then compound 3; then compound 2.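

Notes on the chain-carbon position: in this assay an open-chain group does better here than the ring-bearing groups, and a 3.4-fold lower number from compound 1 to compound 4 (0.53 log units; beyond the scatter) shows that neopentyl also outperforms the cyclopentyl of the earlier best compound, so a saturated ring is not needed at this place. Going by these compounds alone, the distance from the aromatic groups is also larger than the earlier steps showed, with a 21-fold lower number from compound 3 to compound 4 (1.32 log units; beyond the scatter) and a 110-fold lower number from compound 2 to compound 4 (2.04 log units; beyond the scatter). Among the four compounds, both groups without an aromatic ring give lower numbers than both groups with one, no compound shown goes against this order, and compound 4 has the lowest number, with all three of its steps beyond the scatter. The data shown offer no measured explanation for these differences.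

Open, from the compounds shown here alone, is whether a straight pentyl chain would keep the number of compound 4, which would separate the effect of the branched end of neopentyl from that of chain length alone. Also open, going by these compounds, are a cyclohexyl group, which would compare directly with the aryl rings, and a chain ending in an amine or a hydroxyl group.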